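A few compounds are considered here, and "the series" means these few. Any claim that something is new, unique, unknown or untested is made for them only; others in the source may bear on it.

Measured compounds:
compound 1, `COc1ccc(-c2n[nH]cc2N2CCNCC2)cc1`: > 10000 nM
compound 2, `c1ccc(-c2n[nH]cc2N2CCNCC2)cc1`: > 10000 nM

The read-out throughout is an assay on isolated protein for binding affinity to 5-hydroxytryptamine receptor 1E (Homo sapiens); a higher number here means a weaker inhibitor, a lower number a stronger inhibitor. The value for compound 1 is a limit of the assay, not a number. The value for compound 2 is likewise a limit of the assay. Among the compounds with values here, the only measured step, hydrogen in place of methoxy on an aromatic carbon, is a step that the two limits leave unreadable from compound 1 to compound 2; its size cannot be read, because of the limit of > 10000 nM in this assay, at which 2 of the 2 values shown sit. Compound 2 therefore stands at the assay limit and nowhere else on the numbers shown.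

Compound 3 is `Clc1ccc(-c2n[nH]cc2N2CCNCC2)cc1`. It differs from compound 2 by chloro in place of hydrogen on an aromatic carbon. Within the data shown here, no measured step bears on this change: the one step that exists, from compound 1 to compound 2, is itself unreadable, and both values shown sit at the same limit. No direction of change can be read from the series.

With nothing in the series pointing away from the limit, compound 3 is expected to remain at or near it, and the step that the limit leaves unreadable from compound 2 to compound 3 is expected to be none that can be told apart from the limit. For compound 3 the estimate in this assay is 20000 nM, within the range 5000 nM to 80000 nM, most likely again reported only as a limit.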

Compound 3, inhibition constant: > 10000 nM
Compound 3: a limit, no number; the forecaster's own chance of this, stated with the estimate: 80%; the middle value lies beyond the limit too.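

Compound 3 reads > 10000 nM in this assay as a limit of the assay and not a number. No new step can be read among compound 1, compound 2 and compound 3, because all their values sit at one limit: the limit of > 10000 nM in this assay, at which 3 of the 3 values shown sit.

The compounds shown leave open whether methoxy, hydrogen or chloro at this place makes any difference to binding.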